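A few compounds are considered here, and "the series" means these few. Any claim that something is new, unique, unknown or untested is made for them only; others in the source may bear on it.

In a functional assay on MGC-803 cells (Homo sapiens) for inhibition, read by MTT assay, with a stated time of 48 h (on this read-out lower numbers stand for stronger inhibition and higher numbers for weaker inhibition), compound 3 `C/C=C/C(=O)N(Cc1ccc(OC)c(OC)c1)c1cc(OC)c(OC)c(OC)c1` gives 20100 nM, the highest of the two numerical values in the series, and compound 1 `C/C=C/C(=O)N(Cc1ccc(OC)c([N+](=O)[O-])c1)c1cc(OC)c(OC)c(OC)c1` gives 590 nM. Compound 2 `COc1cc(NCc2ccccc2)cc(OC)c1OC` returns only a limit, > 80000 nM.

The next structure, compound 4 `C/C=C/C(=O)N(Cc1ccc(OC)c(N)c1)c1cc(OC)c(OC)c(OC)c1`, carries amino in place of methoxy on an aromatic carbon, ortho to a methoxy group and meta to a large group: amino in place of methoxy on an aromatic carbon.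

Among the compounds with values here, one measured step bears on this change, and it involves the same aromatic carbon. Methoxy in place of nitro gives a 34-fold higher number from compound 1 to compound 3 (1.53 log units; beyond the scatter), a large loss and beyond the scatter. That single pair shows that this assay can respond strongly to the group on this carbon, with methoxy the less favourable of the two groups tested there. Amino itself has not been tested in the series, so this step guides the direction of the expectation more firmly than its size.

A move to a lower number is expected, probably beyond the scatter but smaller than the step between the nitro and methoxy compounds. The estimated change is a 6.7-fold lower number from compound 3 to compound 4 (0.83 log units; beyond the scatter). For compound 4 the estimated value is 3000 nM, with an expected range of 400 nM to 20000 nM.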

Compound 4, half-maximal inhibitory concentration: 150 nM
Beside the measured number, compound 4's estimate is 20-fold (1.30 log units) above it; the whole stated range lies above it.
By their numbers in this assay, from the lowest: compound 4; then compound 1; then compound 3. At a limit, above all of these: compound 2.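

In this assay, three groups can now be compared on this aromatic carbon, and amino in place of methoxy gives the largest step seen there: a 130-fold lower number from compound 3 to compound 4 (2.13 log units; beyond the scatter). The earlier pair showed only that methoxy was the less favourable of two groups, whereas the further step, a 3.9-fold lower number from compound 1 to compound 4 (0.59 log units; beyond the scatter), shows that nitro is not the most favourable group tested at this position. With both steps beyond the scatter, compound 4 stands lowest among the three compounds that differ at this carbon, and the order from the lowest number is amino, nitro, methoxy.

No measurement shown here accounts for the size of these steps. On these data alone, whether the gain is particular to amino or extends to a methylamino, hydroxyl or acetamido group on the same carbon remains open, as does whether the methoxy group that stays on this ring is needed for the amino result.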